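Swapping phenyl for trifluoromethyl on the shared core

The compounds below may be only part of what the source reports. "The series", "measured", "known", "first", "only" and "open" are said of these compounds alone.

In a functional assay on the whole organism (Myocardium) with Canis familiaris (Canis lupus familiaris) as the target, at a dose of 8.75 mg/kg by the intravenous route (on this read-out lower numbers stand for an effect already at smaller amounts and higher numbers for an effect only at larger amounts of compound), compound 1 (`COc1cc2nc(O)nc(C(C)C)c2cc1OC`) gives 1.39 mg/kg and compound 2 (`COc1cc2nc(O)nc(-c3ccccc3)c2cc1OC`) gives 4.1 mg/kg as the higher of the two numbers. Compound 3 (`COc1cc2nc(O)nc(C(F)(F)F)c2cc1OC`) carries trifluoromethyl in place of phenyl on an aromatic carbon. For the measured compounds named here, the one measured step at this place, phenyl in place of isopropyl, gave a 2.9-fold higher number from compound 1 to compound 2 (0.47 log units; beyond the scatter) and counts as modest. Compound 1 at 1.39 mg/kg also has no ring there, so a modest drop looks likely in this assay for this ring-free group. The expected step is a 2.1-fold lower number from compound 2 to compound 3 (0.31 log units; beyond the scatter) on this scale. For compound 3 the estimated value is 2 mg/kg with 0.7 mg/kg to 6 mg/kg as the expected range.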

Compound 3, dose for half-maximal effect: > 8.75 mg/kg
Compound 3: no number, only a limit; the forecaster's own chance of this, stated with the estimate: 3%; at least 4.3-fold (0.64 log units) between middle value and limit.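

In this assay, the ring-free trifluoromethyl does not follow the ring-free isopropyl, so having no ring at this place is not enough to keep the number low. The change from phenyl gives an at least 2.1-fold higher number from compound 2 to compound 3 (0.32 log units; beyond the scatter), and the change from isopropyl gives an at least 6.2-fold higher number from compound 1 to compound 3 (0.79 log units; beyond the scatter). Both steps rest on a limit for compound 3, not a number, so their full size is unknown: the limit of > 8.75 mg/kg in this assay, at which 1 of the 3 values shown sits.

Still open, from the compounds shown here alone, is how far the number for compound 3 lies beyond that limit. Also open, going by these compounds, is where a methyl group, an amine or a longer chain at this place would fall.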